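Pyrimidinyl Isomers in a Glycine Transporter Amide Series

This account rests on a few compounds, and the source may have more. Where it says the series, first, only, none or still open, it means among the compounds named here.

Compound 1 `COc1cc(C(F)(F)F)cc(SC)c1C(=O)NC1(c2ccc(F)cc2)CCCN(C)C1` — 26 nM
Compound 2 `COc1cc(C(F)(F)F)cc(SC)c1C(=O)NC1(c2cccc(F)c2)CCCN(C)C1` — 48 nM
Compound 3 `COc1cc(C(F)(F)F)cc(SC)c1C(=O)NC1(c2ncccn2)CCCN(C)C1` — > 10000 nM (a limit)

Of the compounds shown here, three with a shared core have been tested in an assay on cells for inhibition of sodium- and chloride-dependent glycine transporter 1 (Homo sapiens); on this read-out lower numbers stand for an effect already at smaller amounts and higher numbers for an effect only at larger amounts of compound. Compound 1 gives 26 nM and compound 2 gives 48 nM. For compound 3 the assay reports no number but only a limit, > 10000 nM. Compound 3 therefore sits at the limit of > 10000 nM in this assay, at which 1 of the 3 values shown sits, the weakest position among the three values shown.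

The step of a 1.8-fold higher number from compound 1 to compound 2 (0.27 log units; within the scatter) is small. The steps of an at least 380-fold higher number from compound 1 to compound 3 (2.58 log units; beyond the scatter) and an at least 200-fold higher number from compound 2 to compound 3 (2.31 log units; beyond the scatter) are both large, so the pyrimidin-2-yl group, in place of either fluorophenyl, takes the compound out of the measurable range.

Compound 4 `COc1cc(C(F)(F)F)cc(SC)c1C(=O)NC1(c2ccncn2)CCCN(C)C1` is not yet measured. It differs from compound 3 in one place: pyrimidin-4-yl in place of pyrimidin-2-yl on a saturated ring carbon. For the measured compounds named here, none of the measured steps exchanges one pyrimidinyl for another, so the nearest guidance is that compound 3, the only pyrimidinyl compound, is at the limit. Compound 4 is therefore expected to stay near that limit, and the step of a number no higher from compound 3 to compound 4 (the limit leaves the size open) is estimated to be none beyond the scatter, with a real chance that again only a limit is reported. For compound 4 the estimate in this assay is 10000 nM, with a range from 2000 nM to 50000 nM.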

Compound 4, half-maximal effective concentration: 1700 nM
Beside the measured number, compound 4's estimate is 5.9-fold (0.77 log units) above it, and the stated range ends above it.
By their numbers in this assay, from the lowest: compounds 1 and 2 (each within the scatter of the next); then compound 4. At a limit, above all of these: compound 3.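

In this assay the exchange of pyrimidin-2-yl for pyrimidin-4-yl gives an at least 5.8-fold lower number from compound 3 to compound 4 (0.76 log units; beyond the scatter), with the same atoms joined differently, so a pyrimidinyl group on this saturated ring carbon need not take the compound out of the measurable range. From the compounds shown here alone, the full size of that step stays open, since the value of compound 3 is only a limit: the limit of > 10000 nM in this assay, at which 1 of the 4 values shown sits. Pyrimidin-4-yl still falls well short of either fluorophenyl group, with a 35-fold higher number from compound 2 to compound 4 (1.55 log units; beyond the scatter) and a 65-fold higher number from compound 1 to compound 4 (1.82 log units; beyond the scatter), so the recovery within the pyrimidinyl pair is only partial.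

The compounds shown leave open why the two pyrimidinyl isomers differ, and whether the recovery is particular to pyrimidin-4-yl or also extends to other rings on this carbon, such as pyrimidin-5-yl or a pyridinyl group. They also leave open whether a fluorine, a methyl group or an amine on the pyrimidin-4-yl ring would narrow the remaining distance to compound 1 and compound 2.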